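The source may hold more compounds than are shown below. What is called first, only, known or untested is meant among the compounds shown, and "the series" means these compounds.

In an ADME assay on Vero cells (Chlorocebus sabaeus) for cytotoxicity, read by MTT assay, with a stated time of 72 h (on this read-out lower numbers stand for stronger inhibition and higher numbers for weaker inhibition), three compounds have been measured:

- Compound 1 `CCn1cc(C(=O)N2N=C(c3cc4ccccc4o3)CC2c2ccccc2OC)c(=O)c2ccc(C)nc21`: > 187000 nM, a limit
- Compound 2 `CCn1cc(C(=O)N2N=C(c3cc4ccccc4o3)CC2c2ccccc2C(=O)O)c(=O)c2ccc(C)nc21`: > 196000 nM, a limit
- Compound 3 `CCn1cc(C(=O)N2N=C(c3cc4ccccc4o3)CC2c2ccc(Cl)cc2)c(=O)c2ccc(C)nc21`: > 160000 nM, a limit

None of these values is a number in the ordinary sense, so the three compounds cannot be ranked. Compound 3, like the other two, stands only as a limit, as the limit of > 160000 nM in this assay, at which 1 of the 3 values shown sits, records.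

The next compound is compound 4 `CCn1cc(C(=O)N2N=C(c3cc4ccccc4o3)CC2c2ccco2)c(=O)c2ccc(C)nc21`, with furan-2-yl in place of 4-chlorophenyl on a saturated ring carbon.

Two measured steps change the group at this same place, a step that the two limits leave unreadable from compound 1 to compound 3 and a step that the two limits leave unreadable from compound 2 to compound 3. A third, a step that the two limits leave unreadable from compound 1 to compound 2, changes a group on the aromatic ring at that place. None of the three has a size that can be read. All three compounds, with their different groups, gave only limits in this assay, and that is the whole of the guidance available. No step beyond the scatter is therefore expected in this assay, and compound 4 is expected to be reported as a limit as well. The expected change is a step that the limit leaves unreadable from compound 3 to compound 4. For compound 4 the estimated value is 200000 nM. The expected range for this estimate runs from 100000 nM to 350000 nM.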

Compound 4, half-maximal inhibitory concentration: > 185000 nM
Compound 4: no number, only a limit; the forecaster's own chance of this, stated with the estimate: 85%; the middle value does not contradict the limit.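

In this assay compound 4 gives > 185000 nM, which is a limit. Its steps from compound 1, compound 2 and compound 3 each join two limits, and none of them can be read. The compounds shown leave open what value, if any, could be given for any of the four in this assay, and whether the group on the saturated ring carbon changes it.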